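Swapping 1,3-oxazol-2-yl for phenyl in compound 1

The source may hold more compounds than are shown below. What is called first, only, known or untested is meant among the compounds shown, and "the series" means these compounds.

compound 1 (`CN(c1ncco1)c1cnc(NCc2c(F)ccc3c2CCO3)n2cnnc12`): 67000 nM
compound 2 (`Cc1nccn1-c1cnc(NCc2c(F)ccc3c2CCO3)c2cn[nH]c(=O)c12`): 7000 nM
compound 3 (`Cc1cc(-c2cnc(NCc3c(F)ccc4c3CCO4)c3cn[nH]c(=O)c23)n(C)n1`): 1000 nM

In a physicochemical assay for solubility, read by LC-MS, in phosphate buffer, with a stated time of 24 h, at pH 7.4 (on this read-out higher numbers stand for higher solubility and lower numbers for lower solubility), compound 1 has the highest of these three numbers. Compound 4 (`CN(c1ccccc1)c1cnc(NCc2c(F)ccc3c2CCO3)n2cnnc12`) has not been measured yet. It keeps the core of compound 1 and changes one group (phenyl in place of 1,3-oxazol-2-yl on a nitrogen on an aromatic ring), which in words is phenyl in place of 1,3-oxazol-2-yl on a nitrogen on an aromatic ring.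

Going by the values given here, no measured step makes this exact swap. The closest comparison also trades one aromatic ring group for another (a 7.0-fold lower number from compound 2 to compound 3 (0.85 log units; beyond the scatter)), but it does so on an aromatic carbon and on a different core. Among the compounds with values here, this modest drop is the only guide, so it carries limited weight. A step in the same direction and of similar or smaller size is expected (a 4.5-fold lower number from compound 1 to compound 4 (0.65 log units; beyond the scatter)), though the range must stay wide. For compound 4 the estimated value in this assay is 15000 nM, with an expected range from 3000 nM to 60000 nM for the coming measurement.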

Compound 4, solubility: < 2000 nM
Compound 4 was reported as a limit; the forecaster's own chance of this, stated with the estimate: 5%; at least 7.5-fold (0.87 log units) between middle value and limit.
By their numbers in this assay, from the lowest: compound 3; then compound 2; then compound 1.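

At this nitrogen on an aromatic ring, trading one aromatic ring for another has a large effect in this assay, and this is the first such step shown within the core of compound 1: an at least 33-fold lower number from compound 1 to compound 4 (1.52 log units; beyond the scatter). Compound 4 carries a limit rather than a number: the limit of < 2000 nM in this assay, at which 1 of the 4 values shown sits. The change takes out a five-membered aromatic ring with 2 hetero atoms and 2 hydrogen-bond acceptors and puts in a six-membered aromatic ring of carbon only, but these data cannot separate which of those differences matters.

From the compounds shown here alone, it remains open whether an amine or a carboxylic acid carried on the phenyl would restore a higher number in this assay. Going by these compounds, it is also open how a saturated carbon chain would read in place of either ring at this nitrogen.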